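Amide aryl variation on the chromone series: compound 4

The source may hold more compounds than are shown below. What is called first, only, known or untested is meant among the compounds shown, and "the series" means these compounds.

Three amides on the shared core have been measured in a functional assay on HCC1937 cells (Homo sapiens) for antiproliferative activity, read by CCK-8 assay, with a stated time of 72 h; a higher number here means a weaker inhibitor, a lower number a stronger inhibitor. Compound 1 `O=C(Nc1cccc(-c2oc3cc(-c4ccc(F)cc4)ccc3c(=O)c2O)c1)c1ccc(Cl)cc1` gives 4030 nM; compound 2 `COc1cccc(C(=O)Nc2cccc(-c3oc4cc(-c5ccc(F)cc5)ccc4c(=O)c3O)c2)c1` gives 18900 nM; compound 3 `Cc1cccc(C(=O)Nc2cccc(-c3oc4cc(-c5ccc(F)cc5)ccc4c(=O)c3O)c2)c1` gives 8030 nM. On these numbers compound 3 stands second highest of the three; its nearest neighbour is compound 1, with a 2.0-fold higher number from compound 1 to compound 3 (0.30 log units; within the scatter), and its furthest is compound 2, with a 2.4-fold lower number from compound 2 to compound 3 (0.37 log units; beyond the scatter).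

Compound 4 `COc1ccc(C(=O)Nc2cccc(-c3oc4cc(-c5ccc(F)cc5)ccc4c(=O)c3O)c2)c(F)c1` differs from compound 3 by 2-fluoro-4-methoxyphenyl in place of 3-methylphenyl on a carbonyl carbon. Within the data shown here, the steps that bear on this change are a 4.7-fold higher number from compound 1 to compound 2 (0.67 log units; beyond the scatter) and a 2.4-fold lower number from compound 2 to compound 3 (0.37 log units; beyond the scatter): in both, the methoxy-bearing aryl gave the higher number, modestly beyond the scatter. Among the measured compounds shown here, compound 4 again carries a methoxy, with a fluorine added and the substituent positions shifted, for which no measured step exists. A modest rise in the number is therefore expected for compound 4, roughly a 1.6-fold higher number from compound 3 to compound 4 (0.21 log units; within the scatter), with the added fluorine left uncounted. Compound 4 is estimated at 13000 nM in this assay, within a range of 5000 nM to 32000 nM.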

Compound 4, half-maximal inhibitory concentration: 24500 nM
The estimate for compound 4 lay 1.9-fold (0.28 log units) below the measured number; low and high end bracket the measured number.
By their numbers in this assay, from the lowest: compounds 1 and 3 (each within the scatter of the next); then compounds 2 and 4 (each within the scatter of the next).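

In this assay, the 2-fluoro-4-methoxyphenyl amide gives a 3.1-fold higher number from compound 3 to compound 4 (0.48 log units; beyond the scatter) and a 6.1-fold higher number from compound 1 to compound 4 (0.78 log units; beyond the scatter), so a second methoxy-bearing aryl on this carbonyl carbon also sits beyond the scatter from both the 3-methylphenyl and the 4-chlorophenyl amides, and none of the four compounds goes against this. The step between the two methoxy-bearing aryls, a 1.3-fold higher number from compound 2 to compound 4 (0.11 log units; within the scatter), shows that 2-fluoro-4-methoxyphenyl in place of 3-methoxyphenyl brings no readable change. No evidence on the reason for these differences is available.

Going by these compounds, compounds 2 and 4 differ in both the fluorine and the methoxy placement, so the contribution of each remains open. Also open, on these data alone, is how an amine or a carboxylic acid on this aryl, or a longer chain in its place, would read.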